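The source may hold more compounds than are shown below. What is called first, only, known or untested is meant among the compounds shown, and "the series" means these compounds.

Measured compounds:
compound 1 `Cc1ccc(OC[C@@H]2[C@H]3CC[C@H](c4nc(C(=O)O)cs4)O[C@H]3C[C@H]2O)cc1`: 27 nM
compound 2 `O=C(O)c1csc([C@H]2CC[C@@H]3[C@@H](COc4cccc(Cl)c4)[C@H](O)C[C@@H]3O2)n1`: 6.5 nM
compound 3 `O=C(O)c1csc([C@H]2CC[C@@H]3[C@@H](CCCOc4ccccc4)[C@H](O)C[C@@H]3O2)n1`: 10 nM

All three were run in a functional assay on CHO cells for agonist activity at prostaglandin E2 receptor EP2 subtype (Homo sapiens), read by HTRF and cAMP accumulation, with a stated time of 30 min; a lower number here means that less compound is needed, a higher number that more compound is needed for the effect. Compound 2 has the lowest number of the three; its gap to compound 3 is a 1.5-fold higher number from compound 2 to compound 3 (0.19 log units; within the scatter), so the two are not separable, while the other step, a 4.2-fold lower number from compound 1 to compound 2 (0.62 log units; beyond the scatter), stands clear of the scatter. The change from compound 1 to compound 3 is a 2.7-fold lower number from compound 1 to compound 3 (0.43 log units; beyond the scatter).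

Compound 4 `O=C(O)c1csc([C@H]2CC[C@@H]3[C@@H](COc4ccccc4C(F)(F)F)[C@H](O)C[C@@H]3O2)n1` has not yet been measured in this assay. It differs from compound 2 in one place: 2-(trifluoromethyl)phenyl in place of 3-chlorophenyl on an oxygen on a saturated carbon.

Among the measured compounds shown here, of the measured steps, only the pair from compound 1 to compound 2 touches the aryl ring on this oxygen, and it shows that a change of substituent on that ring can move the number by a modest but clear amount. For the measured compounds named here, no measured pair tells how a 2-(trifluoromethyl)phenyl behaves here, and the two closest compounds, compound 2 and compound 3, sit within the scatter of each other. The expectation for compound 4 is therefore a step of about a 1.5-fold higher number from compound 2 to compound 4 (0.19 log units; within the scatter), with no direction that can be argued from these data beyond a possible small rise. Compound 4 is expected to give 10 nM in this assay, within a range of 3 nM to 35 nM.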

Compound 4, half-maximal effective concentration: 0.5 nM
The estimate for compound 4 lay 20-fold (1.30 log units) above the measured number, and the stated range ends above it.
By their numbers in this assay, from the lowest: compound 4; then compounds 2 and 3 (each within the scatter of the next); then compound 1.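

In this assay, among the compounds shown here, the aryl ring on this oxygen proves far more decisive than the earlier compounds indicated: the only earlier step between ring substituents, a 4.2-fold lower number from compound 1 to compound 2 (0.62 log units; beyond the scatter), was modest, whereas a 13-fold lower number from compound 2 to compound 4 (1.11 log units; beyond the scatter) is large. The same 2-(trifluoromethyl)phenyl also gives a large step from the 4-methylphenyl, a 54-fold lower number from compound 1 to compound 4 (1.73 log units; beyond the scatter), so the gain holds against both of the other aryl groups carried on this oxygen. No measurement at hand bears on what lies behind this result.

It remains open whether the trifluoromethyl group itself is required, since no other group is shown in its place; a nitrile or a methoxy group on the same ring would test this. Also open, from the compounds shown here alone, is whether the 2-(trifluoromethyl)phenyl keeps its effect on the longer chain of compound 3, where the oxygen stands further from the core.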